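The compounds below may be only part of what the source reports. "The series", "measured", "known", "first", "only" and "open" are said of these compounds alone.

Compound 1 `CC(=O)N1N=C(c2cccc3ccccc23)CC1c1ccccc1[N+](=O)[O-]` is the starting point of this small set. In a functional assay on OVCAR cells (Homo sapiens) for cytotoxicity, read by sulforhodamine B assay, with a stated time of 48 h (on this read-out lower numbers stand for stronger inhibition and higher numbers for weaker inhibition), compound 1 gives 4320 nM. Compound 2 `CC(=O)N1N=C(c2cccc3ccccc23)CC1c1cccc(Cl)c1Cl` carries a single change on the same core, (2,3-dichlorophenyl in place of 2-nitrophenyl on a saturated ring carbon), and in this assay compound 2 gives 19100 nM. That change brought a 4.4-fold higher number from compound 1 to compound 2 (0.65 log units; beyond the scatter).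

Compound 3 `O=CCN1N=C(c2ccc3ccccc3c2)CC1c1ccccc1[N+](=O)[O-]` has the same atoms as compound 1 joined differently; the difference between the two cores is not broken down here. In this assay compound 3 gives 3480 nM, a number close to that of compound 1, the two being within the scatter of each other, and one that stands well apart from compound 2.

Compound 4 `O=CCN1N=C(c2ccc3ccccc3c2)CC1c1cccc(Cl)c1Cl` has not yet been measured. It is related to compound 3 by 2,3-dichlorophenyl in place of 2-nitrophenyl on a saturated ring carbon, the same kind of change that leads from compound 1 to compound 2. The surroundings of the place are not identical: in compound 1 the saturated ring carbon is next to the ring atom that bears an acetyl group, whereas in compound 3 it is next to the ring atom that bears a formylmethyl group. Within the data shown here, on the basis of the single step seen so far, a 4.4-fold higher number from compound 1 to compound 2 (0.65 log units; beyond the scatter), a step of similar size is expected, a 4.3-fold higher number from compound 3 to compound 4 (0.63 log units; beyond the scatter), with the weaker anchoring that one precedent allows. Compound 4 is therefore expected to give about 15000 nM in this assay, estimated to fall between 6000 nM and 40000 nM.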

Compound 4, half-maximal inhibitory concentration: 15100 nM
For compound 4 the middle estimate is 1.0-fold (0.00 log units) below the measured one, within the range that was stated.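

In this assay the change from 2-nitrophenyl to 2,3-dichlorophenyl gives a step of matching size on both cores: the same change on two cores in this assay, a 4.4-fold higher number (0.65 log units; beyond the scatter) from compound 1 to compound 2 and a 4.3-fold higher number (0.64 log units; beyond the scatter) from compound 3 to compound 4, 1.0-fold (0.01 log units) apart, within the scatter of two such steps. On the second core the change brings a 4.3-fold higher number from compound 3 to compound 4 (0.64 log units; beyond the scatter), so within these two pairs of compounds the step seen on the core of compound 1 carries over to the core of compound 3 in both direction and size. Among these compounds, this rests on only two pairs, one assay and one change, so it does not show that the step would hold on any other core or for any other replacement of 2-nitrophenyl, and it gives no reason why the number rises.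

The compounds shown leave open how much of the similarity between the two cores depends on the acetyl and formylmethyl groups, since the difference between these cores is not broken down, and whether the step would survive if a longer chain ending in an amine or a carboxylic acid stood on that ring atom instead. They also leave open whether a phenyl ring with a single chlorine or with a methoxy group would fall in line with 2-nitrophenyl, with 2,3-dichlorophenyl, or with neither.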